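Cyclopent-3-en-1-yl replaces 4-hydroxycyclohexyl on the shared core

This account rests on a few compounds, and the source may have more. Where it says the series, first, only, none or still open, it means among the compounds named here.

In an ADME assay on Huh-7 cells (Homo sapiens) for cytotoxicity (a lower number here means that less compound is tolerated, a higher number that more compound is tolerated), compound 2 (`O=C(c1nc2scc(C3CC3)n2c1Cl)N1CCN([C@H]2CC[C@H](O)CC2)C(=O)C1`) gives > 10000 nM, which is a limit and not a number. Compound 1 (`O=C(c1nc2scc(C3CC3)n2c1Cl)N1CCN(C2CCCC2)C(=O)C1`), which carries cyclopentyl, gives > 10000 nM, also a limit. Thus the limit of > 10000 nM in this assay, at which 2 of the 2 values shown sit, describes everything measured so far. Compound 3 (`O=C(c1nc2scc(C3CC3)n2c1Cl)N1CCN(C2CC=CC2)C(=O)C1`) differs from compound 2 in one place: cyclopent-3-en-1-yl in place of 4-hydroxycyclohexyl on an amide-type nitrogen in a ring. For the measured compounds named here, the only measured step is a step that the two limits leave unreadable from compound 1 to compound 2, so it offers no size to carry over. With compound 1 at > 10000 nM, no change beyond the scatter is expected in this assay. The expected step is a step that the limit leaves unreadable from compound 2 to compound 3. The estimate for compound 3 is 12000 nM, with an expected range of 6000 nM to 25000 nM.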

Compound 3, half-maximal cytotoxic concentration: > 10000 nM
Compound 3: only a limit was reported (the forecaster's own chance of this, stated with the estimate: 85%); the middle value is on the limit's open side.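

In this assay, for the compounds shown here, compound 3 gives > 10000 nM as a limit and not a number, so no step among compound 1, compound 2 and compound 3 can be read. The compounds shown leave open at what concentration any of them becomes toxic to these cells: the limit of > 10000 nM in this assay, at which 3 of the 3 values shown sit.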